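A few compounds are considered here, and "the series" means these few. Any claim that something is new, unique, unknown or untested is made for them only; others in the source may bear on it.

The measurements come from a functional assay on HL-60 cells (Homo sapiens) for cytotoxicity, read by luminescence and CellTiter-Glo, with a stated time of 3 days (on this read-out lower numbers stand for stronger inhibition and higher numbers for weaker inhibition), run on three compounds that share a salicylanilide-like core. Compound 1 `Cc1ccc(C(=O)Nc2ccc(C#N)cc2)c(O)c1` gives 2420 nM. Compound 3 `Cc1ccc(O)c(C(=O)Nc2ccc(C#N)cc2)c1` gives 3920 nM, and compound 2 `O=C(Nc1ccc(Cl)c(C(F)(F)F)c1)c1cc(F)ccc1O` gives 600 nM. Among these three numbers compound 1 stands second highest: its nearest neighbour is compound 3, whose number is a little higher but still within the scatter, so the two cannot be told apart; compound 2 lies furthest away, with a lower number that falls beyond the scatter.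

Compound 4 `N#Cc1ccc(NC(=O)c2ccc(Br)cc2O)cc1` has not yet been measured in this assay. It differs from compound 1 in one place: bromo in place of methyl on an aromatic carbon. Going by the values given here, no pair of measured compounds isolates this exchange, so its effect has to be guessed. From compound 1 to compound 4 the step is expected to be a 1.6-fold lower number from compound 1 to compound 4 (0.21 log units; within the scatter), a small move toward a lower number that may well stay within the scatter. For compound 4 the expected value in this assay is 1500 nM, with a likely range from 500 nM to 4500 nM.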

Compound 4, half-maximal inhibitory concentration: 1210 nM
Estimate against measurement, compound 4: 1.2-fold (0.09 log units) above, and the stated range covers the measured number.
By their numbers in this assay, from the lowest: compounds 2, 4, 1 and 3 (each within the scatter of the next, the first and the last beyond it).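

In this assay the exchange of methyl for bromo on this aromatic carbon, meta to a hydroxy group and para to a large group, gives a 2.0-fold lower number from compound 1 to compound 4 (0.30 log units; within the scatter) and so cannot be told apart from no change at all. Going by these compounds alone, this is the first direct reading at this position, and it shows that the position can carry either a methyl or a bromo without a clear shift in the number. Nothing at hand explains this result.

The compounds shown leave open whether an amine, a carboxylic acid or a longer chain at this position would move the number beyond the scatter. They also leave open whether the same exchange would give a similar step with a different group on the other ring.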